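A sulfanyl linker gives way to a carbon chain

This account rests on a few compounds, and the source may have more. Where it says the series, first, only, none or still open, it means among the compounds named here.

Compound 1 `CCOC(=O)c1c(CSc2nccn2C)nc2cc(OC)c(OC)cc2c1-c1ccc(OC)c(OC)c1`: 60%
Compound 2 `CCOC(=O)c1c(CSc2nccn2C)nc2cc(OC)c(OC)cc2c1-c1ccc(OC)cc1`: 64%
Compound 3 `CCOC(=O)c1c(CSc2nccn2C)nc2cc(OC)c(OC)cc2c1-c1ccc(Cl)cc1`: 41%

Three measured compounds share one core and differ only in the aryl group bound to it. In a functional assay on the whole organism for inhibition, with Rattus norvegicus as the target, at a dose of 50 mg/kg by the oral route (on this read-out higher numbers stand for more inhibition at the one dose given (going by the name of the read-out) and lower numbers for less inhibition), compound 1 gives 60%, the second highest of the three numbers. Compound 2 gives 64%, and the step of a number 4 percentage points higher from compound 1 to compound 2 (within the scatter) stays within the scatter, so the two cannot be told apart. Compound 3 gives 41%; the step of a number 19 percentage points lower from compound 1 to compound 3 (beyond the scatter) and the step of a number 23 percentage points lower from compound 2 to compound 3 (beyond the scatter) both lie beyond the scatter and are of modest size.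

Compound 4 `CCOC(=O)c1c(CCc2nccn2C)nc2cc(OC)c(OC)cc2c1-c1ccc(OC)c(OC)c1` keeps the 3,4-dimethoxyphenyl group of compound 1 and changes the chain instead: (1-methyl-1H-imidazol-2-yl)methyl in place of (1-methyl-1H-imidazol-2-yl)sulfanyl on a saturated chain carbon bound to an aromatic carbon. Going by the values given here, no measured step touches this part of the molecule; all three concern the aryl group alone. The expectation for compound 4 therefore rests on the shape of the change rather than on a precedent, and a step of a number 10 percentage points lower from compound 1 to compound 4 (within the scatter) is estimated, small and possibly not beyond the scatter. In this assay compound 4 is expected to give about 50%, within a range from 25% to 75%.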

Compound 4, a percentage reported as inhibition, in the whole organism at one dose (the size of the read-out at that dose, not a potency): 75%
Compound 4: the middle estimate sits 25 percentage points below what was measured, and the stated range covers the measured number.
By their numbers in this assay, from the lowest: compound 3; then compounds 1 and 2 (each within the scatter of the next); then compound 4.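

Going by these compounds alone, the step of a number 15 percentage points higher from compound 1 to compound 4 (beyond the scatter) in this assay shows that the read-out answers to the chain as well as to the aryl group, the only part varied among the earlier compounds. The sulfur of the (1-methyl-1H-imidazol-2-yl)sulfanyl group is not needed for inhibition at this dose: (1-methyl-1H-imidazol-2-yl)methyl, with the same number of heavy atoms and 2 hydrogen-bond acceptors where the leaving group has 3, serves at least as well on this saturated chain carbon. No measurement offered here explains why this exchange raises the number.

The compounds shown leave open whether an oxygen atom or an amine nitrogen in the same link would behave like the carbon of compound 4, and whether a longer chain between the imidazole ring and the core would raise the number further or lower it. They also leave open whether the 2-(1-methyl-1H-imidazol-2-yl)ethyl chain would give a similar step when paired with the 4-methoxyphenyl group of compound 2 or the 4-chlorophenyl group of compound 3, since it is shown here only with the 3,4-dimethoxyphenyl group.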